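The compounds below may be only part of what the source reports. "The series", "measured", "known", "first", "only" and "open" are said of these compounds alone.

Measured compounds:

Compound 1, `COc1ccc(OC)c(COc2cc(NC(=O)c3ccc(I)cc3)ccc2N(C)S(C)(=O)=O)c1`, in a functional assay on SK-BR-3 cells (Homo sapiens) for antiproliferative activity, read by MTT assay, with a stated time of 48 h (on this read-out higher numbers stand for weaker inhibition and lower numbers for stronger inhibition), compound 1 gives 1.21 nM.
Compound 2, `COc1ccc(OC)c(COc2cc(NC(=O)c3ccc4ccccc4c3)ccc2N(C)S(C)(=O)=O)c1`, in this assay compound 2 gives 16.6 nM.
Compound 3, `COc1ccc(OC)c(COc2cc(NC(=O)c3ccc(I)cc3)ccc2NS(C)(=O)=O)c1`, in this assay compound 3 gives 11.8 nM.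

Compound 4, `COc1ccc(OC)c(COc2cc(NC(=O)c3ccc4ccccc4c3)ccc2NS(C)(=O)=O)c1`, has not yet been measured. It is related to compound 3 by the change (naphthalen-2-yl in place of 4-iodophenyl on a carbonyl carbon), and the same change has already been made once among the measured compounds: from compound 1 to compound 2, as naphthalen-2-yl in place of 4-iodophenyl on a carbonyl carbon. That step produced a 14-fold higher number from compound 1 to compound 2 (1.14 log units; beyond the scatter). The two cores on which the change sits differ from each other by hydrogen in place of methyl on a sulfonamide nitrogen, a difference that by itself produced a 9.8-fold higher number from compound 1 to compound 3 (0.99 log units; beyond the scatter). The "place" of the change is the same in both pairs, so this is the same change rather than merely the same kind.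

Because the earlier step gave a 14-fold higher number from compound 1 to compound 2 (1.14 log units; beyond the scatter), the step from compound 3 to compound 4 is expected to be of similar size, estimated as a 10-fold higher number from compound 3 to compound 4 (1.01 log units; beyond the scatter). Whether the two changes add up fully on the same core is not known from these three compounds alone. Compound 4 is therefore expected to give about 120 nM in this assay, with a plausible range from 40 nM to 400 nM.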

Compound 4, half-maximal inhibitory concentration: 13.3 nM
Estimate against measurement, compound 4: 9.0-fold (0.96 log units) above, and the stated range ends above it.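

In this assay, naphthalen-2-yl in place of 4-iodophenyl on a carbonyl carbon gives a 1.1-fold higher number from compound 3 to compound 4 (0.05 log units; within the scatter) on the core with hydrogen on the sulfonamide nitrogen, so the step seen on the core with methyl does not carry over: the same change on two cores in this assay, a 14-fold higher number (1.14 log units; beyond the scatter) from compound 1 to compound 2 and a 1.1-fold higher number (0.05 log units; within the scatter) from compound 3 to compound 4, 12-fold (1.09 log units) apart, beyond the scatter of two such steps Likewise, hydrogen in place of methyl on a sulfonamide nitrogen gives a 1.2-fold lower number from compound 2 to compound 4 (0.10 log units; within the scatter) when naphthalen-2-yl is present, which differs from the step seen with 4-iodophenyl: the same change on two cores in this assay, a 9.8-fold higher number (0.99 log units; beyond the scatter) from compound 1 to compound 3 and a 1.2-fold lower number (0.10 log units; within the scatter) from compound 2 to compound 4, 12-fold (1.09 log units) apart, beyond the scatter of two such steps Among these four compounds, each change therefore depends on what stands at the other place, but this does not show why, or whether the same holds for any other group at either place.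

The compounds shown leave open whether an ethyl group on the sulfonamide nitrogen would behave like methyl or like hydrogen. They also leave open whether 4-bromophenyl or unsubstituted phenyl on the carbonyl carbon would follow 4-iodophenyl or naphthalen-2-yl.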